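The source may hold more compounds than are shown below. What is called first, only, known or untested is meant among the compounds shown, and "the series" means these compounds.

Compound 1 `C=C1CCC(c2csc(/C=C(\C)C(N)=O)c2)CC1` — > 50000 nM
Compound 2 `C/C(=C\c1cc(-c2ccc(C#N)cc2)cs1)C(N)=O` — > 50000 nM

Both measured compounds were tested in a functional assay on A549 cells (Homo sapiens) for cytotoxicity, read by CCK-8 assay, with a stated time of 24 h (a lower number here means a stronger inhibitor, a higher number a weaker inhibitor), and neither gave a number. Compound 1 reached only the limit of the assay, > 50000 nM. Compound 2 likewise reached only the limit, > 50000 nM. Among the measured compounds shown here, compound 2 therefore stands exactly where every value so far stands: at the limit of > 50000 nM in this assay, at which 2 of the 2 values shown sit. For the measured compounds named here, nothing distinguishes the two measured compounds from each other, and no step between them can be read.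

Compound 3 `C/C(=C\c1cc(-c2ccc(Cl)cc2)cs1)C(N)=O` differs from compound 2 in one place: chloro in place of cyano on an aromatic carbon of a six-membered aromatic ring of carbon only, para to a large group. Going by the values given here, no measured pair shows what such an exchange does here, so the size of the step cannot be gauged from the data; the most that can be said is that both known points sit at the limit. Compound 3 is expected to show much the same, with an estimate of 60000 nM, in the range 20000 nM to 150000 nM. The step from compound 2 to compound 3 is expected to be a step that the limit leaves unreadable from compound 2 to compound 3, nothing beyond the usual scatter.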

Compound 3, half-maximal inhibitory concentration: > 50000 nM
Compound 3 was reported as a limit; the forecaster's own chance of this, stated with the estimate: 75%; the middle value lies beyond the limit too.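

Compound 3 is reported only as a limit (> 50000 nM) of the assay. In this assay no step can be read from compound 2 to compound 3, because both sit at the same limit: the limit of > 50000 nM in this assay, at which 3 of the 3 values shown sit.

The compounds shown leave open which change to the shared core, if any, would give a value in this assay that is a number rather than a limit.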